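The source may hold more compounds than are shown below. What is called first, only, known or untested is meant among the compounds shown, and "the series" means these compounds.

Of the compounds shown here, three of one shared core have been measured so far. Compound 1 `Cc1cc(C)cc(C(=O)N(CC(=O)NCc2ccccc2)Cc2ccc(C(=O)Nc3cc(-c4ccccc4)ccc3N)cc2)c1` carries a phenyl group on the aminobenzamide ring; in an assay on Sf9 cells for inhibition of protein deacetylase HDAC6 (Homo sapiens), read by fluorescence, with a stated time of 90 min (a higher number here means a weaker inhibitor, a lower number a stronger inhibitor), compound 1 gives > 10000 nM, which is a limit of the assay and not a number. Compound 2 `Cc1cc(C)cc(C(=O)N(CC(=O)NCc2ccccc2)Cc2ccc(C(=O)Nc3cc(F)ccc3N)cc2)c1` likewise reaches only a limit, > 10000 nM, so the step from compound 1 to compound 2, a step that the two limits leave unreadable from compound 1 to compound 2, cannot be read. Compound 3 `Nc1ccccc1NC(=O)c1ccc(CN(CC(=O)NCc2ccccc2)C(=O)c2cccnc2)cc1` also stops at a limit, > 10000 nM. Every value shown therefore sits at the same limit (the limit of > 10000 nM in this assay, at which 3 of the 3 values shown sit), and compound 3 stands nowhere above or below the others on the numbers available.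

Compound 4 `Cc1cc(C)cc(C(=O)N(CC(=O)NCc2ccccc2)Cc2ccc(C(=O)Nc3ccccc3N)cc2)c1` differs from compound 3 in one place: 3,5-dimethylphenyl in place of pyridin-3-yl on a carbonyl carbon. No measured step covers this exchange, and the one step shown is itself unreadable. Because all three values sit at the limit of > 10000 nM in this assay, at which 3 of the 3 values shown sit, compound 4 is expected to stay at that limit as well, with an expected step that the limit leaves unreadable from compound 3 to compound 4 that means no change beyond the scatter. The estimate for compound 4 in this assay is 15000 nM, ranging from 5000 nM to 50000 nM.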

Compound 4, half-maximal inhibitory concentration: > 10000 nM
Compound 4 gave a limit, no number (the forecaster's own chance of this, stated with the estimate: 85%); the middle value is on the limit's open side.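

Compound 4 gives > 10000 nM in this assay, which is a limit and not a number. Going by these compounds alone, no step from compound 1, compound 2 or compound 3 to compound 4 can be read, since every value sits at the same limit: the limit of > 10000 nM in this assay, at which 4 of the 4 values shown sit. The compounds shown leave open which change to the shared core, if any, would give a readable number.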